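Same ring-nitrogen swap, second core: what to expect

The compounds below may be only part of what the source reports. "The series", "measured", "known", "first", "only" and "open" are said of these compounds alone.

Measured so far:
Compound 1 `COc1cc(/C=N/c2c(C#N)ncn2-c2ccc(F)cc2)cc(OC)c1OC`: 13700 nM
Compound 2 `COc1cc(/C=N/c2c(C#N)ncn2-c2ccc(F)cc2)ccc1O`: 20100 nM
Compound 3 `COc1cc(/C=N/c2c(C#N)ncn2Cc2ccc(F)cc2)cc(OC)c1OC`: 17500 nM

All three were tested in a functional assay on T47D cells (Homo sapiens) for antiproliferative activity, read by MTT assay, with a stated time of 48 h (a lower number here means a stronger inhibitor, a higher number a weaker inhibitor), and all three numbers lie close together, within the usual scatter of one another. The difference between the core of compound 1 and the core of compound 2 is not broken down here. Compound 3 differs from compound 1 by one change, (4-fluorobenzyl in place of 4-fluorophenyl on an aromatic nitrogen), and that change gave a 1.3-fold higher number from compound 1 to compound 3 (0.11 log units; within the scatter). Compound 4 `COc1cc(/C=N/c2c(C#N)ncn2Cc2ccc(F)cc2)ccc1O` is not yet measured; it differs from compound 2 by 4-fluorobenzyl in place of 4-fluorophenyl on an aromatic nitrogen. The place of the change is described in the same words for both pairs, so it is the same change made on a second core. Because the step of a 1.3-fold higher number from compound 1 to compound 3 (0.11 log units; within the scatter) is small, the step from compound 2 to compound 4 is expected to be similar, a 1.2-fold higher number from compound 2 to compound 4 (0.09 log units; within the scatter), resting on that single earlier pair. Compound 4 is therefore estimated to give 25000 nM in this assay, with a plausible range from 12000 nM to 52000 nM.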

Compound 4, half-maximal inhibitory concentration: 21500 nM
Estimate against measurement, compound 4: 1.2-fold (0.07 log units) above; the measured number falls inside the stated range.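

In this assay, putting 4-fluorobenzyl in place of 4-fluorophenyl on the aromatic nitrogen gave a 1.1-fold higher number from compound 2 to compound 4 (0.03 log units; within the scatter), so on this second core the swap again made no difference that can be told from scatter. Set side by side, the two steps agree, and the change carries from one core to the other without a visible shift: the same change on two cores in this assay, a 1.3-fold higher number (0.11 log units; within the scatter) from compound 1 to compound 3 and a 1.1-fold higher number (0.03 log units; within the scatter) from compound 2 to compound 4, 1.2-fold (0.08 log units) apart, within the scatter of two such steps. Among these compounds, this rests on just two pairs, and it shows only that the swap is silent on these two cores in this one assay, not that the two groups can be exchanged freely on other cores or in other tests.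

The compounds shown leave open what a longer chain, such as 2-(4-fluorophenyl)ethyl, or a group carrying an amine or a carboxylic acid would do on that same nitrogen. They also leave open whether any change at this place can move the number beyond the scatter at all.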